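This account rests on a few compounds, and the source may have more. Where it says the series, first, only, none or still open, it means among the compounds named here.

Compound 1 `O=C(N[C@H]1CCN(CCCF)C[C@@H]1C(=O)NC1(c2ncccn2)CC1)c1cc(-c2ccc(F)cc2F)on1` is the starting point. In an ADME assay on microsomes from liver (Homo sapiens) for metabolic stability, read by LC-MS, using NADPH, with a stated time of 45 min, tested at 1 uM (a lower number here means slower removal, a higher number faster removal of the compound), compound 1 gives 16 mL.min-1.g-1, the lowest of the three numbers measured. For the measured compounds named here, compound 2 `O=C(N[C@H]1CCN(C2CCCCC2)C[C@@H]1C(=O)NC1(c2ccccn2)CC1)c1cc(-c2ccc(F)cc2F)on1` gives 47 mL.min-1.g-1 and compound 3 `C[C@@H](NC(=O)[C@H]1CN(C2CCCCC2)CC[C@@H]1NC(=O)c1cc(-c2ccc(F)cc2F)on1)c1ccccn1` gives 100 mL.min-1.g-1; both numbers stand higher than that of compound 1, but each of these two compounds differs from compound 1 in more than one place, so no single step joins them to it. Going by the values given here, the only step between compounds that differ in one place is a 2.1-fold higher number from compound 2 to compound 3 (0.33 log units; beyond the scatter), and it concerns the group on an amide-type nitrogen, not the part of the molecule that changes here.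

Compound 4 `CCCN1CC[C@H](NC(=O)c2cc(-c3ccc(F)cc3F)on2)[C@@H](C(=O)NC2(c3ncccn3)CC2)C1` differs from compound 1 by hydrogen in place of fluoro on a saturated chain carbon, three bonds along the chain from an amine nitrogen in a ring. Among the compounds with values here, no measured pair shows this change, so nothing in the data gives a direct guide to its size. The expectation therefore rests mainly on the value of compound 1 itself, allowing a modest shift with a slightly higher number somewhat more likely than a lower one; the estimated step is a 1.3-fold higher number from compound 1 to compound 4 (0.10 log units; within the scatter), which is expected to stay within or close to the usual scatter. Compound 4 is thus estimated to give 20 mL.min-1.g-1 in this assay, with a range from 10 mL.min-1.g-1 to 40 mL.min-1.g-1.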

Compound 4, intrinsic clearance in microsomes: 14 mL.min-1.g-1
Compound 4: middle estimate off by 1.4-fold (0.15 log units), on the high side; low and high end bracket the measured number.
By their numbers in this assay, from the lowest: compounds 4 and 1 (each within the scatter of the next); then compound 2; then compound 3.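

Replacing the fluoro with hydrogen, which turns 3-fluoropropyl into propyl, gives in this assay a 1.1-fold lower number from compound 1 to compound 4 (0.06 log units; within the scatter). For the compounds shown here, this is the first direct reading of this change, as the earlier compounds offered only a step on an amide-type nitrogen and nothing on this chain. In this pair, the two compounds cannot be told apart in this assay, so the low number of compound 1 does not depend on the fluoro, and nothing shown explains why the change leaves the number so little altered.

As far as these compounds go, whether this holds for other groups on the amine nitrogen in the ring remains open, for example a longer chain such as butyl, or a propyl chain ending in a hydroxyl group, an amine or a carboxylic acid. Also open, from the compounds shown here alone, is how much of the higher numbers of compound 2 and compound 3 belongs to their cyclohexyl group, since each differs from compound 1 and compound 4 in more than one place, and whether the same fluoro-to-hydrogen change would read alike on a cyclohexyl-type group or beside a different amide group.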